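Replacing the aryl ring on the cyclopropane with thiophen-3-yl

The source may hold more compounds than are shown below. What is called first, only, known or untested is meant among the compounds shown, and "the series" means these compounds.

Compound 3 `CC[C@H](C)[C@H](N)CN(C(=O)[C@@H]1C[C@H]1c1ccc(F)c(F)c1)c1ccc(-c2ccccc2)cc1` carries a 3,4-difluorophenyl on a saturated ring carbon of the shared core. In a functional assay for agonist activity at G protein-coupled receptor 88 (Homo sapiens), read by HTRF and cAMP accumulation (on this read-out lower numbers stand for an effect already at smaller amounts and higher numbers for an effect only at larger amounts of compound), compound 3 gives 720 nM, the lowest of the two numbers available. Its nearest neighbour is compound 1 `CC[C@H](C)[C@H](N)CN(C(=O)[C@@H]1C[C@H]1c1cccc(C)c1)c1ccc(-c2ccccc2)cc1`, which in this assay gives 1200 nM; the step of a 1.7-fold lower number from compound 1 to compound 3 (0.22 log units; within the scatter) lies within the scatter. Compound 2 `CC[C@H](C)[C@H](N)CN(C(=O)[C@@H]1C[C@H]1c1ccc(C#N)cc1)c1ccc(-c2ccccc2)cc1` gives in this assay only the limit > 25000 nM and no number (the limit of > 25000 nM in this assay, at which 1 of the 3 values shown sits). The step of an at least 20-fold higher number from compound 1 to compound 2 (1.31 log units; beyond the scatter) is large, and so is the step of an at least 34-fold lower number from compound 2 to compound 3 (1.54 log units; beyond the scatter).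

Compound 4 `CC[C@H](C)[C@H](N)CN(C(=O)[C@@H]1C[C@H]1c1ccsc1)c1ccc(-c2ccccc2)cc1` differs from compound 3 in one place: thiophen-3-yl in place of 3,4-difluorophenyl on a saturated ring carbon. The measured steps show that swapping a 3-methylphenyl for a 3,4-difluorophenyl on this carbon changed little, while the 4-cyanophenyl pushed the value beyond the limit; the thiophen-3-yl of compound 4 carries neither a nitrile nor fluorine, so the author expects a step closer to the small one than to the large ones. Compound 4 is expected to give about 1500 nM, between 500 nM and 6000 nM, in this assay. This estimate means a step of a 2.1-fold higher number from compound 3 to compound 4 (0.32 log units; beyond the scatter), which the author expects to stay within or just beyond the scatter.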

Compound 4, half-maximal effective concentration: 450 nM
Compound 4: middle estimate off by 3.3-fold (0.52 log units), on the high side; measured number outside the range, below it.
By their numbers in this assay, from the lowest: compounds 4, 3 and 1 (each within the scatter of the next, the first and the last beyond it). At a limit, above all of these: compound 2.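

In this assay, thiophen-3-yl on this saturated ring carbon reads like the 3,4-difluorophenyl, with the step of a 1.6-fold lower number from compound 3 to compound 4 (0.20 log units; within the scatter), so a five-membered aromatic ring with a sulfur atom serves here as well as a six-membered aromatic ring of carbon only. Against the 3-methylphenyl, the step of a 2.7-fold lower number from compound 1 to compound 4 (0.43 log units; beyond the scatter) is modest but beyond the scatter, which gives this position its first measured difference outside the scatter between two compounds with actual numbers, as compounds 1 and 3 lie within the scatter of each other. The step of an at least 55-fold lower number from compound 2 to compound 4 (1.74 log units; beyond the scatter) is large, yet it is only a bound, as compound 2 stands at a limit and not at a number: the limit of > 25000 nM in this assay, at which 1 of the 4 values shown sits.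

The compounds shown leave open whether a thiophen-2-yl or a pyridin-3-yl on this carbon would read like compound 4. They also leave open whether the step to compound 2 belongs to the nitrile as such or to its place on the phenyl ring, a question that a 3-cyanophenyl or a 4-methylphenyl could separate.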